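The source may hold more compounds than are shown below. What is called first, only, known or untested is meant among the compounds shown, and "the series" means these compounds.

In an in vitro ADME assay on microsomes from liver (Homo sapiens) for pharmacokinetics, read by LC-MS (on this read-out lower numbers stand for slow clearance and higher numbers for fast clearance), compound 1 (`Cc1nc2cc(OC(F)(F)F)ccc2n1-c1ccc(C(=O)NC2CC2)s1`) gives 7 mL/min/kg and compound 2 (`Cc1nc2ccc(C(F)(F)F)cc2n1-c1ccc(C(=O)NC2CC2)s1`) gives 8 mL/min/kg while compound 3 (`COc1cccc2c1nc(C)n2-c1ccc(C(=O)NC2CC2)s1`) gives 4 mL/min/kg with the shared core. Compound 3 lies within the scatter of compound 1 and of compound 2, so the three values do not separate. Compound 4 (`Cc1nc2c(C#N)cccc2n1-c1ccc(C(=O)NC2CC2)s1`) differs from compound 3 by cyano in place of methoxy on an aromatic carbon with cyano in place of methoxy on an aromatic carbon. For the measured compounds named here, no measured pair differs in one place only. With compound 3 at 4 mL/min/kg as the starting point, no step beyond the scatter is expected in this assay and no direction is favoured. The estimate amounts to a 1.3-fold higher number from compound 3 to compound 4 (0.10 log units; within the scatter) as an expected step within the scatter. Compound 4 is estimated at 5 mL/min/kg with an expected range from 2.5 mL/min/kg to 11 mL/min/kg in this assay.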

Compound 4, clearance: < 4 mL/min/kg
Compound 4 gave a limit, no number; the forecaster's own chance of this, stated with the estimate: 5%; middle value at least 1.2-fold (0.09 log units) from the limit.
By their numbers in this assay, from the lowest: compounds 3, 1 and 2 (each within the scatter of the next).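

In this assay compound 4 gives < 4 mL/min/kg, which is a limit and not a number. Cyano in place of methoxy on this aromatic carbon gives a number no higher from compound 3 to compound 4 (the limit leaves the size open), the only one-place comparison shown in the series. The size of this step stays unreadable because the value of compound 4 is a limit: the limit of < 4 mL/min/kg in this assay, at which 1 of the 4 values shown sits.

As far as these compounds go, how far the clearance of compound 4 lies from that of compound 3 remains open. Also open, from the compounds shown here alone, is whether an amine or a carboxylic acid on the same aromatic carbon would give a similar read-out.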